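Swapping hydroxy for benzamido on compound 1

This account rests on a few compounds, and the source may have more. Where it says the series, first, only, none or still open, it means among the compounds named here.

Compound 1 `COc1ccc([C@@H]2C/C(=N/OCc3cn(-c4ccc(O)cc4)nn3)c3cc(CC=C(C)C)c(OC)cc3O2)cc1` gives 63%
Compound 2 `COc1ccc([C@@H]2C/C(=N/OCc3cn(-c4ccc(Cl)cc4C)nn3)c3cc(CC=C(C)C)c(OC)cc3O2)cc1` gives 37%

Both numbers come from a functional assay on MCF7 cells (Homo sapiens) for inhibition, read by sulforhodamine B assay, with a stated time of 48 h, tested at 50 uM (on this read-out higher numbers stand for more inhibition of growth at the one concentration tested and lower numbers for less inhibition of growth), and compound 1 holds the higher of the two. The next compound to be tested is compound 3 `COc1ccc([C@@H]2C/C(=N/OCc3cn(-c4ccc(NC(=O)c5ccccc5)cc4)nn3)c3cc(CC=C(C)C)c(OC)cc3O2)cc1`, which keeps the core of compound 1 and alters a single group: benzamido in place of hydroxy on an aromatic carbon. In words, benzamido sits in place of hydroxy on an aromatic carbon.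

Going by the values given here, only one measured step bears on this change. It is a number 26 percentage points lower from compound 1 to compound 2 (beyond the scatter), a modest drop that goes beyond the scatter. That step also takes away the hydroxy group, replacing the whole 4-hydroxyphenyl with 4-chloro-2-methylphenyl. Among the compounds with values here, no measured compound carries benzamido, so this single step is thin evidence, and the group entering compound 3 is much larger than the one that leaves. A fall in this assay of similar or somewhat smaller size therefore seems the most likely outcome, though no change beyond the scatter remains possible.

The expected change is a number 18 percentage points lower from compound 1 to compound 3 (beyond the scatter). For compound 3 the estimated value is 45%, within an expected range from 22% to 66%.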

Compound 3, percent growth inhibition at one concentration: 4%
Compound 3: middle estimate off by 41 percentage points, on the high side; measured number outside the range, below it.
By their numbers in this assay, from the lowest: compound 3; then compound 2; then compound 1.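

In this assay, going by these compounds alone, putting benzamido in place of hydroxy on an aromatic carbon gives a number 59 percentage points lower from compound 1 to compound 3 (beyond the scatter), a large step in which only this one group changes. The earlier step, a number 26 percentage points lower from compound 1 to compound 2 (beyond the scatter), replaced the whole 4-hydroxyphenyl at once, whereas this one shows that the place para to a large group does not tolerate every substituent equally in this read-out, even though hydroxy and benzamido have the same counts of hydrogen-bond donors and acceptors and neither carries a net charge. What does differ in the counts is size, with benzamido bringing more heavy atoms and a six-membered aromatic ring, but no measurement here ties the fall to that difference or to anything else.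

An amino or acetamido group at the same place would help to show whether the fall goes with the amide link itself or with the added ring. A methoxy group or a carboxylic acid there would test how much of the number of compound 1 depends on the hydroxy group that leaves.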